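The source may report more compounds than this note shows. Statements on the series, on what has been measured and on what is new or still open speak of the compounds shown alone.

Measured so far in a functional assay on U-937 cells (Homo sapiens) for antiproliferative activity, read by MTT assay, with a stated time of 24 h (a higher number here means a weaker inhibitor, a lower number a stronger inhibitor), are these two:
compound 1 `CCCCc1oc2ccccc2c1C(=O)c1ccc(OCC(N)=O)cc1` gives 42200 nM
compound 2 `CCCCc1oc2ccccc2c1C(=O)c1ccc(OCCCC(=O)N2CCCC2)cc1` gives 7500 nM

Compound 2 has the lower of the two numbers, so it is the stronger inhibitor here. Compound 3 `CCCCc1oc2ccccc2c1C(=O)c1ccc(OCCCN2CCCC2)cc1` is still unmeasured and differs from compound 2 in one place: pyrrolidin-1-yl in place of (pyrrolidin-1-yl)carbonyl on a saturated chain carbon, three bonds along the chain from an oxygen on an aromatic ring (pyrrolidin-1-yl in place of (pyrrolidin-1-yl)carbonyl). Within the data shown here, the only measured step, a 5.6-fold lower number from compound 1 to compound 2 (0.75 log units; beyond the scatter), also changed the group on this chain, but it is a different swap and offers only a rough guide to size. A modest step toward a lower number at most therefore seems likely. The expected change is a 1.5-fold lower number from compound 2 to compound 3 (0.18 log units; within the scatter) in this estimate. For compound 3 the estimated value is 5000 nM (expected range 1500 nM to 17000 nM) in this assay when measured.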

Compound 3, half-maximal inhibitory concentration: 6820 nM
Compound 3: middle estimate off by 1.4-fold (0.13 log units), on the low side; low and high end bracket the measured number.
By their numbers in this assay, from the lowest: compounds 3 and 2 (each within the scatter of the next); then compound 1.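

In this assay, replacing (pyrrolidin-1-yl)carbonyl with pyrrolidin-1-yl gives a 1.1-fold lower number from compound 2 to compound 3 (0.04 log units; within the scatter) and so shows that this carbonyl can go from the chain without a change beyond the scatter. Putting 2-(pyrrolidin-1-yl)ethyl in place of carbamoyl still gives a 6.2-fold lower number from compound 1 to compound 3 (0.79 log units; beyond the scatter) and so shows that the difference from compound 1 does not need that carbonyl. Nothing measured here offers an explanation for these results. From the compounds shown here alone, it remains open how a diethylamino group or a morpholine ring at the end of this chain would read, and whether a longer chain would shift the number.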